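Swapping Hydroxy for Chloro on the Aryl Ketone

The compounds below may be only part of what the source reports. "The series", "measured", "known", "first", "only" and "open" are said of these compounds alone.

Of the compounds shown here, two that share one core have so far been measured in a functional assay on SR cells (Homo sapiens) for cytotoxicity, read by sulforhodamine B assay, with a stated time of 24 h; a higher number here means a weaker inhibitor of growth, a lower number a stronger inhibitor of growth. Compound 1 `COc1ccc(C(=O)/C=C/c2cc3ccccc3[nH]c2=O)cc1` gives 2830 nM. Compound 2 `O=C(/C=C/c1cc2ccccc2[nH]c1=O)c1ccc(O)cc1` gives 1660 nM. Within the data shown here, the single step between them, a 1.7-fold lower number from compound 1 to compound 2 (0.23 log units; within the scatter), is hydrogen in place of methyl on an oxygen on an aromatic ring. Compound 2 thus holds the lower of the two numbers shown, but its gap to compound 1 lies within the scatter, so neither compound can be called the stronger inhibitor.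

Compound 3 `O=C(/C=C/c1cc2ccccc2[nH]c1=O)c1ccc(Cl)cc1` has not yet been measured in this assay. It differs from compound 2 by chloro in place of hydroxy on an aromatic carbon, on an aromatic carbon of a six-membered aromatic ring of carbon only, para to a large group; cut one bond further out, the change reads 4-hydroxyphenyl to 4-chlorophenyl. Among the measured compounds shown here, only the step from compound 1 to compound 2 touches this ring, and it stayed within the scatter. For the measured compounds named here, no measured step involves a chlorine, so the data give no direct guide. Compound 3 is expected to land near its neighbours, with a step of about a 1.2-fold higher number from compound 2 to compound 3 (0.08 log units; within the scatter) that need not exceed the scatter. The estimate for compound 3 is 2000 nM, with a range from 700 nM to 6000 nM.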

Compound 3, concentration for 50% growth inhibition: 1710 nM
Compound 3: the middle estimate sits 1.2-fold (0.07 log units) above what was measured; the measured number falls inside the stated range.
By their numbers in this assay, from the lowest: compounds 2, 3 and 1 (each within the scatter of the next).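

The aromatic carbon para to a large group has now carried hydroxy, methoxy and chloro, and in this assay the hydroxy-to-chloro swap gives a 1.0-fold higher number from compound 2 to compound 3 (0.01 log units; within the scatter) while the methoxy-to-chloro swap gives a 1.7-fold lower number from compound 1 to compound 3 (0.22 log units; within the scatter). Unlike the earlier step, which only altered the group on an oxygen, these steps replace the oxygen itself with a chlorine, and hydroxy, with its hydrogen-bond donor and acceptor, gives way to chloro, which has neither, yet all three numbers remain within the scatter of one another, so across these three compounds neither the identity of the atom on this carbon nor those counts can be linked to any readable difference in this assay. No other evidence bears on this result.

What the compounds leave open is whether a group of another kind on this same carbon, such as an amine, a carboxylic acid or a longer alkoxy chain, would give a number beyond the scatter from these three. On these data alone, it is also open whether chloro or hydroxy would read the same on a different carbon of this ring, and whether any change to the shared core would do so.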